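Swapping fluoro for chloro on a shared core

A few compounds are considered here, and "the series" means these few. Any claim that something is new, unique, unknown or untested is made for them only; others in the source may bear on it.

Compound 1 `O=C(O)c1cn(C2CC2)c2c(Cl)c(N3CCCC3)c(F)cc2c1=O` gives 150 ug/mL
Compound 2 `CC1CN(c2c(F)cc3c(=O)c(C(=O)O)cn(C4CC4)c3c2F)CC(C)N1` gives 150 ug/mL

In a functional assay on V79 cells (Cricetulus griseus) for cytotoxicity, read by colony formation (a lower number here means a stronger inhibitor, a higher number a weaker inhibitor), compound 1 and compound 2 cannot be told apart, and compound 2 gives 150 ug/mL as its value. Compound 3 `CC1CN(c2c(F)cc3c(=O)c(C(=O)O)cn(C4CC4)c3c2Cl)CC(C)N1` is compound 2 with a single swap, chloro in place of fluoro on an aromatic carbon with all else kept. Among the measured compounds shown here, no measured pair shows this swap alone, so the data offer only a loose guide. Compound 1 also carries a chloro group and gives 150 ug/mL in this assay as its value, so no step beyond the scatter is expected. The expected step of a 1.2-fold lower number from compound 2 to compound 3 (0.06 log units; within the scatter) is therefore small. For compound 3 the estimated value is 130 ug/mL with an expected range from 60 ug/mL to 280 ug/mL in this assay when measured.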

Compound 3, half-maximal inhibitory concentration: 140 ug/mL
Estimate against measurement, compound 3: 1.1-fold (0.03 log units) below; the measured number falls inside the stated range.
By their numbers in this assay, from the lowest: compounds 3, 1 and 2 (each within the scatter of the next).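

In this assay chloro in place of fluoro on the aromatic carbon ortho to the 3,5-dimethylpiperazin-1-yl group gives a 1.1-fold lower number from compound 2 to compound 3 (0.03 log units; within the scatter) and so leaves the read-out unmoved beyond the scatter. With chloro in place, 3,5-dimethylpiperazin-1-yl in place of pyrrolidin-1-yl gives a 1.1-fold lower number from compound 1 to compound 3 (0.03 log units; within the scatter) and is just as quiet. Nothing on hand explains these results.

From the compounds shown here alone, whether a bromo or methoxy group on this carbon would shift the number remains open. Going by these compounds, with all three compounds so close, the parts of the structure that matter to this read-out also remain unknown.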